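This account rests on a few compounds, and the source may have more. Where it says the series, first, only, none or still open, it means among the compounds named here.

Among the measured compounds shown here, compound 3 `N#Cc1cc(C(F)(F)F)cc(C(F)(F)F)c1` is one of three compounds so far measured in an ADME assay for pharmacokinetics, read by HPLC, in phosphate buffer, with a stated time of 72 h, at pH 7.4, tested at 250 uM; a higher number here means that the compound lasts longer, a lower number that the compound disappears faster. In this assay compound 3 gives > 50 h, which is a limit of the assay rather than a number. Compound 2 `C=Cc1cc(C(F)(F)F)cc(C(F)(F)F)c1` likewise reaches > 50 h, again a limit. Compound 1 `C=CC(=O)Oc1cc(C(F)(F)F)cc(C(F)(F)F)c1` stands at the other end with < 0.017 h, also a limit. Two of the three values shown thus sit at the upper limit of > 50 h in this assay, at which 2 of the 3 values shown sit, and one at the lower limit (the limit of < 0.017 h in this assay, at which 1 of the 3 values shown sits). The steps away from compound 1 are large: an at least 2900-fold higher number from compound 1 to compound 2 (3.46 log units; beyond the scatter) and an at least 2900-fold higher number from compound 1 to compound 3 (3.46 log units; beyond the scatter). Between the two upper values the step cannot be read: a step that the two limits leave unreadable from compound 2 to compound 3.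

Compound 4 `FC(F)(F)c1cc(C2CO2)cc(C(F)(F)F)c1` has not yet been measured. It differs from compound 3 by oxiran-2-yl in place of cyano on an aromatic carbon. For the measured compounds named here, none of the measured steps exchanges a cyano for an oxiran-2-yl, so no step bears directly on this change; the measured steps show only that replacing the (vinylcarbonyl)oxy group of compound 1 with either vinyl or cyano carries the half-life from one limit to the other. Compound 4 is therefore expected to give 30 h in this assay, within a range from 5 h to 50 h. The step this estimate implies is an at least 1.6-fold lower number from compound 3 to compound 4 (0.22 log units; that floor lies within the scatter), an expected decrease whose size is uncertain.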

Compound 4, half-life: > 50 h
Compound 4 was reported as a limit; the forecaster's own chance of this, stated with the estimate: 40%; at least 1.6-fold (0.22 log units) between middle value and limit.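

In this assay compound 4 gives > 50 h, which is a limit and not a number. On this aromatic carbon, meta to two trifluoromethyl groups, oxiran-2-yl, with its three-membered non-aromatic ring, now stands with vinyl and cyano as a third group at the upper end of the read-out: the limit of > 50 h in this assay, at which 3 of the 4 values shown sit. Only the comparison with the (vinylcarbonyl)oxy group can be read, as an at least 2900-fold higher number from compound 1 to compound 4 (3.46 log units; beyond the scatter), so the rapid disappearance of compound 1 does not reappear with this ring in place, while the steps among compounds 2, 3 and 4 cannot be read.

The compounds shown leave open how long compounds 2, 3 and 4 actually last in this assay, and whether they differ from one another at all. They also leave open whether an amine or a longer chain ending in a carboxylic acid on the same aromatic carbon would stay at the upper end or move toward the opposite end, which so far compound 1 alone occupies: the limit of < 0.017 h in this assay, at which 1 of the 4 values shown sits.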